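The source may hold more compounds than are shown below. What is called first, only, known or untested is meant among the compounds shown, and "the series" means these compounds.

Working notes on the series.

Two compounds of this series have a number in an assay on HEK293 cells for displacement of a labelled ligand from NPC1-like intracellular cholesterol transporter 1 (Homo sapiens) (on this read-out lower numbers stand for stronger inhibition and higher numbers for weaker inhibition), so far. Compound 1 `CC(C)(C)OC(=O)NC1CCCN(C(=O)CN2CN(c3ccccc3)C3(CCN(C(=O)c4ccc(C5CCCCC5)cc4)CC3)C2=O)C1` gives 4400 nM in this assay. Compound 2 `CCc1nn(CC)c(C2CCN(C(=O)CN3CN(c4ccccc4)C4(CCN(C(=O)c5ccc(C(C)(C)C)cc5)CC4)C3=O)CC2)c1C` gives 2500 nM in this assay. Of these two numbers that of compound 1 is the larger, but the gap to compound 2 lies within the usual scatter of repeated measurements, so the two values are read as the same level and no ranking is made between them.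

Compound 3 `NC(=O)C1CCCN(C(=O)CN2CN(c3ccccc3)C3(CCN(C(=O)c4ccc(C5CCCCC5)cc4)CC3)C2=O)C1` has not been measured in this assay. It differs from compound 1 in one place: carbamoyl in place of (tert-butoxycarbonyl)amino on a saturated ring carbon The shared core of compound 1 is kept unchanged. Going by the values given here, no step between measured compounds is available, so nothing in the data tells how this assay responds to a change of this kind, and the expectation rests on the single value of compound 1 alone.

The change from compound 1 to compound 3 is expected to shift the number in this assay slightly upward, by about a 1.5-fold higher number from compound 1 to compound 3 (0.17 log units; within the scatter), a step that may stay within the scatter. For compound 3 the estimate in this assay is 6500 nM, with a range from 2200 nM to 20000 nM.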

Compound 3, half-maximal inhibitory concentration: 3100 nM
Beside the measured number, compound 3's estimate is 2.1-fold (0.32 log units) above it, and the stated range covers the measured number.
By their numbers in this assay, from the lowest: compounds 2, 3 and 1 (each within the scatter of the next).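

In this assay, the step at this position, a 1.4-fold lower number from compound 1 to compound 3 (0.15 log units; within the scatter), lies within the scatter, so the two groups cannot be told apart on this read-out. Going by these compounds alone, this is the first direct reading for this place, on a saturated ring carbon of a six-membered non-aromatic ring with 1 nitrogen: the 8 heavy atoms of (tert-butoxycarbonyl)amino give way to the 3 heavy atoms of carbamoyl, and the number stays at the same level. No measurement bears on the reason for this result.

The reading covers only these two groups, both without net charge, and only the core of compound 1, so a single step cannot show whether the position is insensitive to substitution in general. Going by these compounds, whether a free amine, a carboxylic acid or a longer chain on this ring carbon would move the number in this assay beyond the scatter remains open, as does whether the same step would read alike with other groups elsewhere on the shared core.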